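Phenyl in Place of Isobutyl: Expected Effect on Growth Inhibition

The source may report more compounds than this note shows. Statements on the series, on what has been measured and on what is new or still open speak of the compounds shown alone.

Compound 1 `CC(C)COC(=O)Nc1ccc([Se]C#N)cc1` was tested in a functional assay on HTB-54 cells (Homo sapiens) for cytotoxicity, read by MTT assay, with a stated time of 72 h (on this read-out lower numbers stand for stronger inhibition of growth and higher numbers for weaker inhibition of growth), where compound 1 gives 27100 nM. Compound 2 `N#C[Se]c1ccc(NC(=O)OCc2ccc([N+](=O)[O-])cc2)cc1` gives 22900 nM in this assay, and the two numbers lie within the scatter of each other, so neither compound can be called the stronger. Compound 3 `N#C[Se]c1ccc(NC(=O)Oc2ccccc2)cc1` is not yet measured; it carries phenyl in place of isobutyl on an oxygen next to a carbonyl group. Going by the values given here, no measured pair shows this exact change, so the step cannot be read from the data. The step from compound 1 to compound 3 is expected to be small, a 1.4-fold lower number from compound 1 to compound 3 (0.13 log units; within the scatter), not beyond the scatter. Compound 3 is estimated at 20000 nM, with a range from 8000 nM to 50000 nM.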

Compound 3, concentration for 50% growth inhibition: 26200 nM
Compound 3: middle estimate off by 1.3-fold (0.12 log units), on the low side; the range from low to high includes it.
By their numbers in this assay, from the lowest: compounds 2, 3 and 1 (each within the scatter of the next).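

Putting phenyl in place of isobutyl on an oxygen next to a carbonyl group gives a 1.0-fold lower number from compound 1 to compound 3 (0.01 log units; within the scatter) in this assay. Going by these compounds alone, this is the first direct reading of this change, and it shows that a ring can replace a chain at this place without a difference that stands out from the scatter. Nothing available here explains why the two groups read alike. Still open, on these data alone, is how a longer chain would read at this place, or a phenyl carrying an amine or a carboxylic acid. The compounds shown also leave open whether this holds in other cell types.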